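Chlorophenyl series: from compound 3 to compound 4

The compounds below may be only part of what the source reports. "The series", "measured", "known", "first", "only" and "open" are said of these compounds alone.

Measured in a functional assay on HepG2 cells (Homo sapiens) for antiproliferative activity, read by MTT assay, with a stated time of 48 h; a lower number here means a stronger inhibitor, a higher number a weaker inhibitor:
- compound 1 `CCn1cc(-c2ccc(Cl)cc2)c(=O)c2cc(F)c(N3CCNCC3)cc21`: 24000 nM
- compound 2 `CCn1cc(-c2cccc(OC)c2)c(=O)c2cc(F)c(N3CCNCC3)cc21`: 13000 nM
- compound 3 `O=c1c(-c2ccc(Cl)cc2)cn(C2CC2)c2cc(N3CCNCC3)c(F)cc12`: 8020 nM

Compound 3 and compound 2 lie within the scatter of each other, and only compound 1 stands clearly apart from compound 3. The next compound to be tested is compound 4 `O=c1c(-c2cccc(Cl)c2)cn(C2CC2)c2cc(N3CCNCC3)c(F)cc12`, which carries 3-chlorophenyl in place of 4-chlorophenyl on an aromatic carbon. It keeps the cyclopropyl group of compound 3.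

For the measured compounds named here, the one measured change on that aromatic carbon, 3-methoxyphenyl in place of 4-chlorophenyl, gave a 1.8-fold lower number from compound 1 to compound 2 (0.27 log units; within the scatter). The modest change of ethyl to cyclopropyl on an aromatic nitrogen, a 3.0-fold lower number from compound 1 to compound 3 (0.48 log units; beyond the scatter), lies elsewhere and only sets the starting level. Going by the values given here, no measured compound yet isolates 3-chlorophenyl itself, so the expectation in this assay is no step beyond the scatter, with a slight lean towards a lower number. The expected step is a 1.1-fold lower number from compound 3 to compound 4 (0.06 log units; within the scatter). For compound 4 the estimated value is 7000 nM, with an expected range of 2800 nM to 17000 nM.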

Compound 4, half-maximal inhibitory concentration: 860 nM
The estimate for compound 4 lay 8.1-fold (0.91 log units) above the measured number; the measured number lies below the stated range.
By their numbers in this assay, from the lowest: compound 4; then compounds 3, 2 and 1 (each within the scatter of the next, the first and the last beyond it).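

In this assay, the 3-chlorophenyl for 4-chlorophenyl exchange gives a 9.3-fold lower number from compound 3 to compound 4 (0.97 log units; beyond the scatter) on the cyclopropyl compounds, although the two groups match in every count of atoms, donors and acceptors. For the compounds shown here, the aromatic carbon therefore responds to where the chlorine sits on the phenyl group, a sensitivity that the only earlier change at this carbon did not show, since 3-methoxyphenyl in place of 4-chlorophenyl gave a 1.8-fold lower number from compound 1 to compound 2 (0.27 log units; within the scatter) on the ethyl compounds. Nothing shown gives a reason for the size of this step.

It remains open whether 3-chlorophenyl gives a step of this size with ethyl on the aromatic nitrogen, as the compounds shown offer no such pair. Also open, on these data alone, is how a phenyl group carrying an amine or a carboxylic acid in place of the chlorine would read in this assay.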